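The source may report more compounds than this note shows. Statements on the series, on what has been measured and on what is new or still open speak of the compounds shown alone.

Compound 2, `COc1ccc(CCCCCCCCOc2ccc(C[S+]([O-])c3cccc(NS(=O)(=O)c4ccccc4)c3)nc2/C=C/C(=O)O)cc1`, gives 147 nM in an assay for binding affinity to leukotriene B4 receptor 1 (Homo sapiens) (a lower number here means a stronger inhibitor, a higher number a weaker inhibitor), the lowest of the three numbers in hand. Going by the values given here, compound 3, `CCCCCCCCCCCCOc1ccc(C[S+]([O-])c2ccccc2C(=O)O)nc1/C=C/C(=O)O`, gives 478 nM, and compound 1, `CCCCCCCCCCCCOc1ccc(COc2cccc(C(=O)O)c2)nc1/C=C/C(=O)O`, gives 1130 nM; the only single-site step among them runs a 2.4-fold lower number from compound 1 to compound 3 (0.37 log units; beyond the scatter), a change on a saturated chain carbon bound to an aromatic carbon. Compound 4, `COc1ccc(CCCCCCCCOc2ccc(C[S+]([O-])c3cccc(N)c3)nc2/C=C/C(=O)O)cc1`, differs from compound 2 by hydrogen in place of phenylsulfonyl on a nitrogen on an aromatic ring, so that (phenylsulfonyl)amino becomes amino. Among the compounds with values here, no measured pair bears on this change: the step from compound 1 to compound 3 alters a different part of the molecule, and compound 2 is the only compound carrying the phenylsulfonyl group, so nothing among the measured values shows what its removal does. With that gap, the estimate for compound 4 is a modestly weaker number, an expected change of a 3.4-fold higher number from compound 2 to compound 4 (0.53 log units; beyond the scatter) in this assay. Compound 4 is therefore expected to give about 500 nM in this assay, within a range from 150 nM to 1600 nM.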

Compound 4, inhibition constant: 4.7 nM
Estimate against measurement, compound 4: 110-fold (2.03 log units) above; measured number outside the range, below it.
By their numbers in this assay, from the lowest: compound 4; then compound 2; then compound 3; then compound 1.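

Read in this assay, the single change of hydrogen in place of phenylsulfonyl on the nitrogen on an aromatic ring produces a large gain (a 31-fold lower number from compound 2 to compound 4 (1.50 log units; beyond the scatter)). Going by these compounds alone, this is the first reading at this position, and it shows that the phenylsulfonyl group is not needed for a low number on this core: within this pair, the free amino group goes with the stronger inhibitor. Nothing at hand accounts for the size of this step.

One pair cannot show whether the result depends on the free amino group itself or simply on the absence of phenylsulfonyl. An acetyl or methylsulfonyl group on the same nitrogen would help separate the two, and the compounds shown do not say how either would read against compound 4.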